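The compounds below may be only part of what the source reports. "The series", "measured", "known", "first", "only" and "open" are said of these compounds alone.

Compound 2 `O=C(O)c1ccccc1-c1ccc(CCc2ncc(Cc3ccc(Cl)cc3)[nH]2)cc1` is the reference point. In an in vitro functional assay on cells for agonist activity at Bombesin receptor subtype-3 (Mus musculus), read by luminescence and calcium flux (on this read-out lower numbers stand for an effect already at smaller amounts and higher numbers for an effect only at larger amounts of compound), compound 2 gives 102 nM, the lowest of the three numbers measured. Compound 3 `CCCCc1cnc(C(CC)Cc2ccc(-c3ccccc3C(=O)O)cc2)[nH]1` stands nearest, and in this assay compound 3 gives 340 nM. Compound 1 `CCCCc1cnc(C(Cc2ccc(-c3ccccc3C(=O)O)cc2)C(C)C)[nH]1` is furthest away, and in this assay compound 1 gives 2240 nM. Among the compounds with values here, the only step measured between compounds differing in one place, a 6.6-fold lower number from compound 1 to compound 3 (0.82 log units; beyond the scatter), concerns a methyl on the chain between the shared core and the aromatic ring, not the group attached to the core itself.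

Compound 4 `CC(C)(C)CCc1cnc(CCc2ccc(-c3ccccc3C(=O)O)cc2)[nH]1` differs from compound 2 by neopentyl in place of 4-chlorophenyl on a saturated chain carbon bound to an aromatic carbon. Within the data shown here, no measured step bears on this exchange. What the data do show is that compound 1 and compound 3, which carry a saturated chain rather than a 4-chlorobenzyl group on the core, give higher numbers than compound 2. On that basis a moderate rise in number is expected for compound 4, a 4.4-fold higher number from compound 2 to compound 4 (0.64 log units; beyond the scatter), with the estimate for compound 4 in this assay being 450 nM, within a range from 120 nM to 1800 nM.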

Compound 4, half-maximal effective concentration: 6.2 nM
The estimate for compound 4 lay 73-fold (1.86 log units) above the measured number; measured number below the stated range.
By their numbers in this assay, from the lowest: compound 4; then compound 2; then compound 3; then compound 1.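

In this assay the exchange gives a 16-fold lower number from compound 2 to compound 4 (1.22 log units; beyond the scatter) and so shows that, on a saturated chain carbon bound to an aromatic carbon, an aromatic ring is not needed for a low number. The 3,3-dimethylbutyl group of compound 4 has no ring and fewer heavy atoms than the 4-chlorobenzyl group of compound 2, yet compound 4 has the lowest number of the four compounds. Nothing available explains the size of this step.

The compounds shown leave open whether a straight hexyl chain, a cyclohexyl ring or an amine at this place would give a similarly low number. They also leave open how an ethyl group on the chain, as carried by compound 3, would act in combination with the 3,3-dimethylbutyl group.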